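A Chlorine Takes the Place of Fluorine on the Aniline

The source may hold more compounds than are shown below. What is called first, only, known or untested is meant among the compounds shown, and "the series" means these compounds.

Compound 1 `Fc1cccc(-c2nc(Nc3ccccc3)c3ccccc3n2)c1` and compound 2 `Fc1ccc(Nc2nc(-c3cccc(F)c3)nc3ccc(F)cc23)cc1` share one core. In a functional assay on COLO 205 cells (Homo sapiens) for cytotoxicity, read by MTT assay, with a stated time of 48 h (a higher number here means a weaker inhibitor, a lower number a stronger inhibitor), compound 1 gives only a limit of the assay, > 50000 nM. Compound 2 reaches no number in this assay either and gives only a limit, > 50000 nM. Both values sit at the limit of > 50000 nM in this assay, at which 2 of the 2 values shown sit, so compound 2 stands beside compound 1 with nothing to separate them. Compound 3 `Fc1cccc(-c2nc(Nc3ccccc3Cl)c3cc(F)ccc3n2)c1` differs from compound 2 by 2-chlorophenyl in place of 4-fluorophenyl on a nitrogen on an aromatic ring. Among the measured compounds shown here, with no measured step to lean on, no step beyond the scatter is expected in this assay. Compound 3 is estimated at 50000 nM, within 10000 nM to 100000 nM. The expected step from compound 2 to compound 3 is a number no higher from compound 2 to compound 3 (the limit leaves the size open).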

Compound 3, half-maximal inhibitory concentration: > 50000 nM
Compound 3 ended at the assay's limit; the forecaster's own chance of this, stated with the estimate: 75%; the middle value sits exactly at the limit.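

In this assay, among the compounds shown here, compound 2 and compound 3 each give only a limit, and no step between them can be read. The compounds shown leave open whether 2-chlorophenyl in place of 4-fluorophenyl changes potency at all, as none of them reaches a number in this assay here.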